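The source may report more compounds than this note shows. Statements on the series, on what has been measured and on what is new or still open speak of the compounds shown alone.

Measured compounds in the series:
- compound 1, `COc1cc2nc(N3CCC(C(=O)NC4CCCC4)CC3)nc(N)c2cc1OC`: in an assay on isolated protein for displacement of a labelled ligand from Adrenergic receptor alpha-1 (Rattus norvegicus) (a lower number here means a stronger inhibitor, a higher number a weaker inhibitor), compound 1 gives 0.63 nM
- compound 2, `COCCNC(=O)C1CCN(c2nc(N)c3cc(OC)c(OC)cc3n2)CC1`: in this assay compound 2 gives 1.13 nM

Among the measured compounds shown here, compound 2 carries the higher of the two numbers measured so far, but its nearest neighbour is compound 1, and the step between them, a 1.8-fold higher number from compound 1 to compound 2 (0.25 log units; within the scatter), stays within the scatter, so the two compounds cannot be ordered against each other on these data.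

The next compound is compound 3, `COc1cc2nc(N3CCC(C(=O)Nc4ccccc4)CC3)nc(N)c2cc1OC`. Relative to compound 2 the change is phenyl in place of 2-methoxyethyl on an amide-type nitrogen. For the measured compounds named here, the only measured step that touches the same position is the one from compound 1 to compound 2, where a cyclopentyl was exchanged for a 2-methoxyethyl on the amide-type nitrogen and the number in this assay moved a 1.8-fold higher number from compound 1 to compound 2 (0.25 log units; within the scatter). A ring in place of a chain at this nitrogen therefore has a precedent, and that precedent moved nothing beyond the scatter. Going by the values given here, no other measured pair bears on the change.

On that basis no step beyond the scatter is expected for compound 3 in this assay, the estimated step being a 1.3-fold lower number from compound 2 to compound 3 (0.10 log units; within the scatter). The number expected for compound 3 in this assay is 0.9 nM, with a range from 0.3 nM to 3 nM.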

Compound 3, inhibition constant: 0.47 nM
For compound 3 the middle estimate is 1.9-fold (0.28 log units) above the measured one; measured number inside the range.
By their numbers in this assay, from the lowest: compounds 3, 1 and 2 (each within the scatter of the next, the first and the last beyond it).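

Among the compounds shown here, at the amide-type nitrogen, this assay now shows a first step beyond the scatter, though a modest one, with phenyl in place of 2-methoxyethyl (a 2.4-fold lower number from compound 2 to compound 3 (0.38 log units; beyond the scatter)). The exchange of cyclopentyl for phenyl at the same nitrogen gives no such separation (a 1.3-fold lower number from compound 1 to compound 3 (0.13 log units; within the scatter)), so these two ring substituents cannot be ordered against each other, and compound 2 is separated from compound 3 but not from compound 1. For the compounds shown here, the chain therefore differs measurably from only one of the two rings, and no measurement on these compounds accounts for that difference.

From the compounds shown here alone, it remains open whether the step from compound 2 to compound 3 reflects the 2-methoxyethyl group itself or would recur with other chains, such as a longer unbranched alkyl chain or a chain ending in an amine or a carboxylic acid. Also open, going by these compounds, is how far the phenyl result extends to benzyl, pyridyl or a phenyl carrying a fluorine or a methoxy group, and whether any of these would separate from compound 1 and compound 3 in this assay.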